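Moving a nitro group on the outer aromatic ring

The source may hold more compounds than are shown below. What is called first, only, known or untested is meant among the compounds shown, and "the series" means these compounds.

Measured in a functional assay on HT-29 cells (Homo sapiens) for antiproliferative activity, read by MTT assay, with a stated time of 72 h; on this read-out higher numbers stand for weaker inhibition and lower numbers for stronger inhibition:
Compound 1 `Cc1ccc(N2CCN(C(=S)SCc3ccc4nc(N)nc(N)c4c3)CC2)cc1`: 3020 nM
Compound 2 `Nc1nc(N)c2cc(CSC(=S)N3CCN(c4ccc(F)cc4F)CC3)ccc2n1`: 5020 nM
Compound 3 `Nc1nc(N)c2cc(CSC(=S)N3CCN(c4ccc([N+](=O)[O-])cc4)CC3)ccc2n1`: 3320 nM

These three compounds share the same core and differ only in the aromatic group on the ring nitrogen. Compound 3 cannot be separated from the other two on these numbers. The measured steps to it are a 1.1-fold higher number from compound 1 to compound 3 (0.04 log units; within the scatter) and a 1.5-fold lower number from compound 2 to compound 3 (0.18 log units; within the scatter). The remaining step, a 1.7-fold higher number from compound 1 to compound 2 (0.22 log units; within the scatter), is also modest. So far, then, changing this group has produced no difference larger than ordinary repeat variation.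

The next compound, compound 4 `Nc1nc(N)c2cc(CSC(=S)N3CCN(c4ccccc4[N+](=O)[O-])CC3)ccc2n1`, contains the same atoms as compound 3, joined differently: 2-nitrophenyl in place of 4-nitrophenyl on an amine nitrogen in a ring. In words, this is 2-nitrophenyl in place of 4-nitrophenyl on an amine nitrogen in a ring. Within the data shown here, no measured pair tests such a shift directly, so the evidence is indirect. The closest guides are the nitro in place of methyl change, a 1.1-fold higher number from compound 1 to compound 3 (0.04 log units; within the scatter), and the change from 2,4-difluorophenyl, a 1.5-fold lower number from compound 2 to compound 3 (0.18 log units; within the scatter). Neither exceeds the scatter, so only a modest shift seems likely, though an untested change could still surprise. The expected result is a 1.1-fold higher number from compound 3 to compound 4 (0.02 log units; within the scatter), which means no expected change beyond the scatter. For compound 4 the estimate is 3500 nM, with an expected range of 1800 nM to 7000 nM.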

Compound 4, half-maximal inhibitory concentration: 4310 nM
The estimate for compound 4 lay 1.2-fold (0.09 log units) below the measured number; measured number inside the range.
By their numbers in this assay, from the lowest: compounds 1, 3, 4 and 2 (each within the scatter of the next).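

In this assay, among these compounds, moving the nitro group so that 2-nitrophenyl replaces 4-nitrophenyl gives a 1.3-fold higher number from compound 3 to compound 4 (0.11 log units; within the scatter) and so offers the first comparison at this position of the same atoms joined differently, and this rearrangement does not separate the two compounds. The new group also stays level with the two other aromatic groups, with a 1.2-fold lower number from compound 2 to compound 4 (0.07 log units; within the scatter) and a 1.4-fold higher number from compound 1 to compound 4 (0.15 log units; within the scatter) as its remaining steps, so all four groups on the ring nitrogen now lie within ordinary repeat variation of one another, whether the group carries methyl, fluorine or nitro. Nothing measured here gives a reason for these small differences or for the lack of a larger one.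

Every group shown on this nitrogen is a substituted phenyl ring, so the range of change tested remains narrow, and a benzyl group, a pyridine ring or a phenyl ring bearing an amine or a carboxylic acid could still give a different picture. From the compounds shown here alone, whether any replacement at this position can move the number beyond the scatter, rather than merely within it, also remains open.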